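The source may hold more compounds than are shown below. What is called first, only, known or untested is meant among the compounds shown, and "the series" means these compounds.

In a functional assay on the whole organism for inhibition, with Rattus norvegicus as the target (a lower number here means that less compound is needed, a higher number that more compound is needed for the effect), the measured compounds stand as follows:

compound 1 `CC1CC/C(=N\Nc2ccccc2)c2nccc(=O)n21`: > 100 umol/kg, a limit of the assay.
compound 2 `CCOC(=O)c1cnc2n(c1=O)C(C)CC/C2=N\Nc1ccccc1`: > 1000 umol/kg, a limit of the assay.
compound 3 `CC1CC/C(=N\Nc2ccccc2)c2ncc(C(=O)NN)c(=O)n21`: > 1000 umol/kg, a limit of the assay.

All three values are limits. Compound 3 sits at the limit of > 1000 umol/kg in this assay, at which 2 of the 3 values shown sit, while compound 1 sits at the limit of > 100 umol/kg in this assay, at which 1 of the 3 values shown sits. The step that the two limits leave unreadable from compound 1 to compound 3 and the step that the two limits leave unreadable from compound 2 to compound 3 give no readable size, and neither does a step that the two limits leave unreadable from compound 1 to compound 2.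

Compound 4 `CC1CC/C(=N\Nc2ccccc2)c2ncc(C#N)c(=O)n21` differs from compound 3 by cyano in place of aminocarbamoyl on an aromatic carbon. Going by the values given here, no measured step bears on this change with a readable size: the three steps between the measured compounds are bounded by limits on both sides. Among the compounds with values here, nothing among the measured compounds points to an effect in either direction, and every measured value is a limit. The most likely outcome is that this assay again reports only a limit for compound 4. The step of a number no higher from compound 3 to compound 4 (the limit leaves the size open) is expected to lie within the scatter. Compound 4 is estimated at 1000 umol/kg, with a range from 300 umol/kg to 3000 umol/kg.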

Compound 4, dose for 50% inhibition: > 1000 umol/kg
Compound 4: a limit, no number; the forecaster's own chance of this, stated with the estimate: 80%; the middle value lies on the limit itself.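

In this assay compound 4 gives > 1000 umol/kg, a limit of the assay. Going by these compounds alone, no step between compound 4 and compound 1, compound 2 or compound 3 can be read. The compounds shown leave open what dose any of the four needs and how any group on this aromatic carbon shifts it.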